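Swapping Nitro for Bromo on the Shared Core

This account rests on a few compounds, and the source may have more. Where it says the series, first, only, none or still open, it means among the compounds named here.

Three measured compounds share one core and one chain of four carbons ending in a phenyl group, and differ only in the group on an aromatic carbon of that core. In an assay on HEK293 cells for inhibition of acid ceramidase (Homo sapiens), with a stated time of 10 min (a lower number here means a stronger inhibitor, a higher number a weaker inhibitor), compound 1 `O=C(c1ccccc1)c1ccc2c(c1)oc(=O)n2C(=O)NCCCCc1ccccc1` gives 29 nM. Compound 2 `COc1ccc(-c2ccc3c(c2)oc(=O)n3C(=O)NCCCCc2ccccc2)cc1` gives 67 nM in this assay, with a 2.3-fold higher number from compound 1 to compound 2 (0.36 log units; beyond the scatter). Compound 3 `O=C(NCCCCc1ccccc1)n1c(=O)oc2cc([N+](=O)[O-])ccc21` gives 3 nM in this assay, the lowest of the three numbers: a 9.7-fold lower number from compound 1 to compound 3 (0.99 log units; beyond the scatter), and a 22-fold lower number from compound 2 to compound 3 (1.35 log units; beyond the scatter).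

Compound 4 `O=C(NCCCCc1ccccc1)n1c(=O)oc2cc(Br)ccc21` differs from compound 3 in one place: bromo in place of nitro on an aromatic carbon. Among the measured compounds shown here, no measured step exchanges nitro for bromo, so the three known steps only frame the case. They show that the group at this position moves this assay over a wide span, and that both alternatives to nitro measured so far, benzoyl in compound 1 and 4-methoxyphenyl in compound 2, sit higher than nitro. Bromo is a third alternative, and compound 4 is therefore expected to give a higher number than compound 3, with an expected step of a 6.7-fold higher number from compound 3 to compound 4 (0.82 log units; beyond the scatter). Compound 4 is estimated at 20 nM in this assay, with a range from 6 nM to 70 nM.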

Compound 4, half-maximal inhibitory concentration: 31 nM
Compound 4: middle estimate off by 1.6-fold (0.19 log units), on the low side; measured number inside the range.
By their numbers in this assay, from the lowest: compound 3; then compounds 1 and 4 (each within the scatter of the next); then compound 2.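

In this assay, a 10-fold higher number from compound 3 to compound 4 (1.01 log units; beyond the scatter) shows that a group of 1 heavy atom, bromo, does not match nitro with its 3 heavy atoms and 2 hydrogen-bond acceptors, so nitro now stands apart from three different groups at this position on the shared core. Bromo and benzoyl cannot be told apart here, given a 1.1-fold higher number from compound 1 to compound 4 (0.03 log units; within the scatter), whereas a 2.2-fold lower number from compound 2 to compound 4 (0.33 log units; beyond the scatter) separates bromo from 4-methoxyphenyl, so the three alternatives to nitro span a much narrower band than the one between them and nitro. Compound 3 therefore remains the one clear outlier at the low end among the four compounds, and nothing available here explains what sets nitro apart from bromo.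

As far as these compounds go, whether another group on this aromatic carbon, such as a nitrile, an amine or a carboxylic acid, would come close to nitro or fall with bromo and benzoyl remains open. From the compounds shown here alone, it is also open whether the gap between nitro and bromo would persist with a longer chain in place of the chain of four carbons ending in a phenyl group.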